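Hydroxy for chloro on the aromatic ring of compound 2

This account rests on a few compounds, and the source may have more. Where it says the series, first, only, none or still open, it means among the compounds named here.

Measured compounds:
Compound 1, `CC1(C)N=C(N)N=C(N)N1c1ccccc1N`: 4.11
Compound 2, `CC1(C)N=C(N)N=C(N)N1c1ccccc1Cl`: 4.86

In an assay for inhibition of Dihydrofolate reductase (Bos taurus), at pH 6.25 (a higher number here means a more potent compound, by a factor of ten per unit of this negative logarithm, a lower number a less potent compound), compound 2 stands highest of the two, with compound 1 the nearest and a number 0.75 log units higher from compound 1 to compound 2 (beyond the scatter). Compound 3, `CC1(C)N=C(N)N=C(N)N1c1ccccc1O`, is not yet measured; it differs from compound 2 by hydroxy in place of chloro on an aromatic carbon. Among the compounds with values here, only one measured step bears on this change: the step from compound 1 to compound 2, which was modest but beyond the scatter. Since hydroxy, like amino, carries a hydrogen-bond donor where chloro carries none, a step back toward compound 1 is expected, of about a number 0.46 log units lower from compound 2 to compound 3 (beyond the scatter). Compound 3 is therefore estimated at 4.4, within 3.9 to 5.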

Compound 3, logarithm of the reciprocal of the active concentration, log(1/C): 3.86
Compound 3: middle estimate off by 0.54 log units, on the high side; the whole stated range lies above it.
By their numbers in this assay, from the lowest: compounds 3 and 1 (each within the scatter of the next); then compound 2.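

In this assay, hydroxy on this aromatic carbon gives up all that chloro held over amino, with a number 1.00 log units lower from compound 2 to compound 3 (beyond the scatter), and it stands level with amino, with a number 0.25 log units lower from compound 1 to compound 3 (within the scatter). Of the three groups at this place, ortho to a large group, chloro alone stands apart, and compound 2 is the most potent of the three. Nothing measured here accounts for this result.

As far as these compounds go, whether fluoro, bromo or methyl would hold the level of chloro remains open. So does whether methoxy would stay level with hydroxy.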